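The source may report more compounds than this note shows. Statements on the series, on what has been measured and on what is new or still open speak of the compounds shown alone.

Compound 1, `Cc1ccccc1NC(=O)c1ccc(/N=N\c2c[nH]c3ccccc23)cc1`: 509000 nM
Compound 2, `O=C(Nc1ccc([N+](=O)[O-])cc1)c1ccc(/N=N\c2c[nH]c3ccccc23)cc1`: 156000 nM

In a functional assay on HCT-116 cells (Homo sapiens) for inhibition, read by MTT assay, with a stated time of 72 h (a higher number here means a weaker inhibitor, a lower number a stronger inhibitor), compound 2 holds the lowest of the two numbers; its nearest neighbour is compound 1, and the step of a 3.3-fold lower number from compound 1 to compound 2 (0.51 log units; beyond the scatter) separates them. Compound 3, `O=C(Nc1cccc([N+](=O)[O-])c1)c1ccc(/N=N\c2c[nH]c3ccccc23)cc1`, differs from compound 2 only in that (3-nitrophenyl in place of 4-nitrophenyl on an amide-type nitrogen); the two have the same atoms, joined differently. No measured step bears on this change: the one step shown, a 3.3-fold lower number from compound 1 to compound 2 (0.51 log units; beyond the scatter), concerns a different exchange on the amide-type nitrogen. Compound 3 is therefore expected to stay close to compound 2, with a step of a 1.2-fold higher number from compound 2 to compound 3 (0.09 log units; within the scatter) not beyond the scatter, so compound 3 is estimated at 190000 nM, within 70000 nM to 500000 nM.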

Compound 3, half-maximal inhibitory concentration: 70100 nM
Estimate against measurement, compound 3: 2.7-fold (0.43 log units) above; low and high end bracket the measured number.
By their numbers in this assay, from the lowest: compound 3; then compound 2; then compound 1.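

In this assay, the place of the nitro group on the phenyl ring matters, even though the atoms stay the same: 3-nitrophenyl in place of 4-nitrophenyl on the amide-type nitrogen gives a step beyond the scatter (a 2.2-fold lower number from compound 2 to compound 3 (0.35 log units; beyond the scatter)). The larger step against 2-methylphenyl (a 7.3-fold lower number from compound 1 to compound 3 (0.86 log units; beyond the scatter)) leaves the 3-nitrophenyl compound with the lowest number of the three. Nothing available explains why the two nitrophenyl groups differ. Still open, as far as these compounds go, is how an aminophenyl or carboxyphenyl group would compare on this nitrogen.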